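Methoxy in Place of Methyl on the Sulfonyl Ring

A few compounds are considered here, and "the series" means these few. Any claim that something is new, unique, unknown or untested is made for them only; others in the source may bear on it.

Compound 1 `COc1cc2c(cc1OC)C(/C(C)=N/NC(N)=S)N(S(=O)(=O)c1ccc(C)cc1)CC2`: in a functional assay on HepG2 cells (Homo sapiens) for cytotoxicity, read by crystal violet staining, with a stated time of 3 days (on this read-out higher numbers stand for weaker inhibition and lower numbers for stronger inhibition), compound 1 gives > 50 ug/mL, which is a limit of the assay rather than a number.
Compound 2 `C/C(=N\NC(N)=S)C1c2ccccc2CCN1S(=O)(=O)c1ccc(C)cc1`: in this assay compound 2 gives 46 ug/mL.

Compound 2 thus carries the only number shown; the other value is a limit (the limit of > 50 ug/mL in this assay, at which 1 of the 2 values shown sits). Compound 3 `COc1ccc(S(=O)(=O)N2CCc3ccccc3C2/C(C)=N/NC(N)=S)cc1` differs from compound 2 by one change (methoxy in place of methyl on an aromatic carbon), methoxy in place of methyl on an aromatic carbon. Within the data shown here, no measured pair shows the effect of this change, so the expected step is small, none beyond the scatter, in either direction. Compound 3 is therefore expected to give 45 ug/mL (range 20 ug/mL to 50 ug/mL), a step of a 1.0-fold lower number from compound 2 to compound 3 (0.01 log units; within the scatter) that may itself end as a limit.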

Compound 3, half-maximal inhibitory concentration: 33.5 ug/mL
The estimate for compound 3 lay 1.3-fold (0.13 log units) above the measured number; measured number inside the range.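

Among these compounds, this is the first measured pair to test this position on the aromatic ring. In this assay, methoxy in place of methyl gives a 1.4-fold lower number from compound 2 to compound 3 (0.14 log units; within the scatter), so 4-methylphenyl and 4-methoxyphenyl cannot be told apart here, even though methoxy adds a hydrogen-bond acceptor. Compound 1 remains a limit rather than a number: the limit of > 50 ug/mL in this assay, at which 1 of the 3 values shown sits.

From the compounds shown here alone, whether an amine or a carboxylic acid at this position would give a step beyond the scatter remains open. Also open, going by these compounds, is whether methoxy in place of methyl would give a similar step on the core of compound 1.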